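This account rests on a few compounds, and the source may have more. Where it says the series, first, only, none or still open, it means among the compounds named here.

Compound 1 `O=C(N[C@H]1CCN(Cc2ccc(C(F)(F)F)cc2)C1)c1ccc(-c2cccs2)cc1` is the starting point here. For the measured compounds named here, in an assay on HEK298 cells for displacement of a labelled ligand from D(4) dopamine receptor (Homo sapiens) (on this read-out lower numbers stand for stronger inhibition and higher numbers for weaker inhibition), compound 1 gives 14 nM, the lowest of the three numbers measured so far; compound 2 `O=C(N[C@H]1CCN(Cc2ccc(OC(F)(F)F)cc2)C1)c1ccc(-c2cccs2)cc1` gives 78 nM and compound 3 `O=C(N[C@H]1CCN(Cc2ccccc2F)C1)c1ccc(-c2cccs2)cc1` gives 33 nM. Compound 4 `O=C(N[C@H]1CCN(Cc2ccc(F)cc2)C1)c1ccc(-c2cccs2)cc1` differs from compound 1 in one place: fluoro in place of trifluoromethyl on an aromatic carbon. Going by the values given here, two measured steps bear on this change, each altering the same part of compound 1: a 5.6-fold higher number from compound 1 to compound 2 (0.75 log units; beyond the scatter) and a 2.4-fold higher number from compound 1 to compound 3 (0.37 log units; beyond the scatter). In both cases moving away from the trifluoromethyl group weakened binding by a modest amount. A modest weakening of similar size is therefore expected for the new step: a 2.5-fold higher number from compound 1 to compound 4 (0.40 log units; beyond the scatter). Compound 4 is expected to give 35 nM, with a likely range from 12 nM to 100 nM.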

Compound 4, inhibition constant: 5 nM
The estimate for compound 4 lay 7.0-fold (0.85 log units) above the measured number; measured number below the stated range.
By their numbers in this assay, from the lowest: compound 4; then compound 1; then compound 3; then compound 2.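

Leaving trifluoromethyl does not always weaken binding in this assay: fluoro at this place gives a 2.8-fold lower number from compound 1 to compound 4 (0.45 log units; beyond the scatter) and so reverses the direction seen with trifluoromethoxy. The swap between fluoro and trifluoromethoxy is the largest step here, with a 16-fold lower number from compound 2 to compound 4 (1.19 log units; beyond the scatter) from that one change. Where the fluorine sits also counts, since 4-fluorophenyl in place of 2-fluorophenyl gives a 6.6-fold lower number from compound 3 to compound 4 (0.82 log units; beyond the scatter) with the rest of the molecule unchanged.

No available data explain these differences. Going by these compounds, whether chloro, methyl or a nitrile at this place would match fluoro remains open.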